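The source may report more compounds than this note shows. Statements on the series, on what has been measured and on what is new or still open speak of the compounds shown alone.

Of the compounds shown here, three of one shared core have been measured in a functional assay on LNCaP cells (Homo sapiens) for cytotoxicity, read by MTT assay, with a stated time of 72 h; a higher number here means a weaker inhibitor, a lower number a stronger inhibitor. Compound 1 `COc1ccc(/C=C/C(=O)/C=C/C2=C(C)CCCC2(C)C)cc1O` gives 9900 nM, and compound 2 `COc1ccc(/C=C/C(=O)/C=C/C2=C(C)CCCC2(C)C)cc1OC` gives 9500 nM. Going by the values given here, the step of a 1.0-fold lower number from compound 1 to compound 2 (0.02 log units; within the scatter) is the only single-point change among the measured compounds. Compound 3 `CC1=C(/C=C/C(=O)/C=C/c2cccc(C(F)(F)F)c2)C(C)(C)CCC1` gives 2800 nM, the lowest of the three numbers; its gap to compound 2 and to compound 1 is beyond the scatter in each case.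

Compound 4 `CC1=C(/C=C/C(=O)/C=C/c2cc(C(F)(F)F)cc(C(F)(F)F)c2)C(C)(C)CCC1` differs from compound 3 by trifluoromethyl in place of hydrogen on an aromatic carbon. Among the compounds with values here, no measured step bears directly on this change: the one step at hand concerns a methyl on an oxygen of another ring and lies within the scatter, and no pair among the measured compounds adds or removes a trifluoromethyl in one place. All that can be said is that compound 3, which already carries one trifluoromethyl, gives the lowest number, while compound 1 and compound 2 give higher ones. On this thin basis the step of a 1.1-fold lower number from compound 3 to compound 4 (0.05 log units; within the scatter) is expected to be small, with no clear direction beyond the scatter. Compound 4 is therefore estimated at 2500 nM in this assay , within a range from 900 nM to 7000 nM.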

Compound 4, half-maximal inhibitory concentration: 8700 nM
The estimate for compound 4 lay 3.5-fold (0.54 log units) below the measured number; the whole stated range lies below it.
By their numbers in this assay, from the lowest: compound 3; then compounds 4, 2 and 1 (each within the scatter of the next).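

Going by these compounds alone, the second trifluoromethyl, placed on an aromatic carbon of the six-membered aromatic ring of carbon only and meta to a trifluoromethyl group, gives the first single-place change on this ring that can be read directly: in this assay there is a 3.1-fold higher number from compound 3 to compound 4 (0.49 log units; beyond the scatter). This position therefore responds to substitution in the direction of a weaker inhibitor, and adding a trifluoromethyl here does not repeat the low number of compound 3, a result that the earlier single-place step, a 1.0-fold lower number from compound 1 to compound 2 (0.02 log units; within the scatter), made at an oxygen on an aromatic ring, could not show. No measurement shown here accounts for the change.

As far as these compounds go, whether a chlorine, a nitrile or an amine at the same place would shift the number in the same direction as trifluoromethyl remains open. Also unresolved is what the single trifluoromethyl of compound 3 itself contributes, since the compounds shown include no pair that adds or removes that first group, so one step at one position is all that can be read for this ring.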